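Swapping Methyl for Cyano on the Aromatic Ring

A few compounds are considered here, and "the series" means these few. Any claim that something is new, unique, unknown or untested is made for them only; others in the source may bear on it.

In a functional assay on SW-620 cells (Homo sapiens) for cytotoxicity, read by sulforhodamine B assay, with a stated time of 48 h (a lower number here means a stronger inhibitor, a higher number a weaker inhibitor), compound 1 `C[C@H]1CC[C@@H]2[C@@H](OC(=O)[C@]23CC(c2ccccc2)=NO3)[C@]2(C)C(=O)C=C[C@@]12O` gives 45400 nM, while compound 2 `Cc1ccc(C2=NO[C@]3(C2)C(=O)O[C@@H]2[C@H]3CC[C@H](C)[C@]3(O)C=CC(=O)[C@@]23C)cc1` gives 2500 nM, the lower of the two numbers and so the stronger inhibitor. For the measured compounds named here, these compounds differ only by methyl in place of hydrogen on an aromatic carbon, and this is the only measured step that bears on the next change: an 18-fold lower number from compound 1 to compound 2 (1.26 log units; beyond the scatter). Compound 3 `C[C@H]1CC[C@@H]2[C@@H](OC(=O)[C@]23CC(c2ccc(C#N)cc2)=NO3)[C@]2(C)C(=O)C=C[C@@]12O` keeps the shared core but has cyano in place of methyl on an aromatic carbon, para to a large group: cyano in place of methyl on an aromatic carbon. Going by the values given here, no measured compound carries cyano, so the direction is uncertain. Still, compound 3 lacks the methyl present in compound 2, so part of that large gain may be lost. A moderate rise in this assay is expected, a 3.2-fold higher number from compound 2 to compound 3 (0.51 log units; beyond the scatter). For compound 3 the estimate is 8000 nM, with an expected range of 1800 nM to 40000 nM.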

Compound 3, half-maximal inhibitory concentration in the SW-620 assay: 53000 nM
Compound 3: middle estimate off by 6.6-fold (0.82 log units), on the low side; the measured number lies above the stated range.
By their numbers in the SW-620 assay, from the lowest: compound 2; then compounds 1 and 3 (each within the scatter of the next).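

In the SW-620 assay, the gain seen with methyl on this ring does not carry over to cyano: there is a 21-fold higher number from compound 2 to compound 3 (1.33 log units; beyond the scatter), while there is only a 1.2-fold higher number from compound 1 to compound 3 (0.07 log units; within the scatter). At this position, then, cyano and hydrogen cannot be told apart, and methyl alone stands out among the three groups. In a physicochemical assay for lipophilicity (a higher number here means a more lipophilic compound, a lower number a more polar compound), compound 2 gives 1.86 and compound 3 gives 1.17. The swap from methyl to cyano also gives a more polar compound, which may be linked to the lost activity, although a single pair cannot establish that: the measured partition coefficient of compound 2, 1.86, and of compound 3, 1.17, a number 0.69 log units lower (beyond the scatter).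

As far as these compounds go, what remains open is whether the gain is specific to methyl or extends to other groups at this position. An ethyl chain, a methoxy group or a chlorine atom in the same place would help separate a link to lipophilicity from an effect unique to methyl.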